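The source may report more compounds than this note shows. Statements on the series, on what has been measured and on what is new or still open speak of the compounds shown alone.

Working notes on the series.

Compound 2 `CC(=O)c1ccc2c(c1)C(n1ccccc1=O)=CC(C)(C)O2` holds the highest number of the three measured in a functional assay (aorta) with Rattus norvegicus as the target (on this read-out higher numbers stand for higher potency (the scale is a negative logarithm) and lower numbers for lower potency), where compound 2 gives 7.37. Compound 1 `COc1ccc2c(c1)C(n1ccccc1=O)=CC(C)(C)O2` gives 6.55 in this assay, and compound 3 `CC1(C)C=C(n2ccccc2=O)c2cc(C(=O)c3ccc(O)cc3)ccc2O1` gives 6.65; both steps away from compound 2 are beyond the scatter, the nearest being compound 3, a number 0.72 log units lower from compound 2 to compound 3 (beyond the scatter), and the furthest compound 1, for which the step is read in the other direction: a number 0.82 log units higher from compound 1 to compound 2 (beyond the scatter).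

Compound 4 `CC1(C)C=C(n2ccccc2=O)c2cc(O)ccc2O1` is yet to be measured in this assay. It differs from compound 2 in one place: hydroxy in place of acetyl on an aromatic carbon.

Going by the values given here, two measured steps bear on this change. The step from methoxy to acetyl on the aromatic carbon, a number 0.82 log units higher from compound 1 to compound 2 (beyond the scatter), shows the acetyl group carrying the whole gain of compound 2 over compound 1. The step that alters the acetyl itself, a number 0.72 log units lower from compound 2 to compound 3 (beyond the scatter), shows that changing this group costs a modest amount. Removing the acetyl altogether in favour of hydroxy is therefore expected to give back most of the gain seen from compound 1 to compound 2, so a modest step downward beyond the scatter is expected: a number 0.77 log units lower from compound 2 to compound 4 (beyond the scatter).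

Compound 4 is thus estimated at 6.6 in this assay, within a range of 6 to 7.2.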

Compound 4, logarithm of the reciprocal of the active concentration, log(1/C): 5.44
Estimate against measurement, compound 4: 1.16 log units above; the whole stated range lies above it.
By their numbers in this assay, from the lowest: compound 4; then compounds 1 and 3 (each within the scatter of the next); then compound 2.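

In this assay, hydroxy on this aromatic carbon falls below every other group shown here: a number 1.93 log units lower from compound 2 to compound 4 (beyond the scatter), a number 1.21 log units lower from compound 3 to compound 4 (beyond the scatter), and a number 1.11 log units lower from compound 1 to compound 4 (beyond the scatter). The earlier compounds shown here showed only that the position responds to a change of carbon-linked carbonyl group or to methoxy; compound 4 adds that the oxygen-linked groups differ sharply from each other, since the methyl on the oxygen alone separates compound 1 from compound 4, and that replacing acetyl does not stop at the level of compound 1 but passes it. Nothing at hand gives a reason for this drop.

Compound 4 is the only compound shown with hydroxy directly on this aromatic carbon, so the compounds do not separate the entering hydrogen-bond donor from the loss of the acetyl carbonyl. An amine or a carboxylic acid on the same carbon, or an ethoxy group as a longer chain on the oxygen, would show whether the low value belongs to hydroxy alone or extends to other groups at this position.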